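The source may report more compounds than this note shows. Statements on the series, on what has been measured and on what is new or still open speak of the compounds shown alone.

In a functional assay on MDA-MB-231 cells (Homo sapiens) for inhibition, read by sulforhodamine B assay, with a stated time of 48 h (on this read-out lower numbers stand for stronger inhibition and higher numbers for weaker inhibition), three compounds that share one core have been measured, and each gave only a limit of the assay rather than a number. Compound 3, with the structure `COc1ccc(C(OCc2ccc(C)cc2)c2cccc3ccccc23)c(OC)c1OC`, gives > 20000 nM, which is a limit. Compound 1, with the structure `COc1ccc(C(OCc2ccccc2)c2cccc3ccccc23)c(OC)c1OC`, gives > 20000 nM, also a limit. Compound 2, with the structure `COc1cc(COC(c2ccc(OC)c(OC)c2OC)c2cccc3ccccc23)cc(OC)c1`, gives > 20000 nM, again a limit. Because of the limit of > 20000 nM in this assay, at which 3 of the 3 values shown sit, none of the steps between these compounds can be read: the step that the two limits leave unreadable from compound 1 to compound 3, the step that the two limits leave unreadable from compound 1 to compound 2 and the step that the two limits leave unreadable from compound 2 to compound 3 all stay hidden behind the limits. For the measured compounds named here, compound 3 thus stands at the limit, with no measured step setting it apart from its neighbours.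

Compound 4, with the structure `COC(=O)c1ccc(COC(c2ccc(OC)c(OC)c2OC)c2cccc3ccccc23)cc1`, differs from compound 3 in one place: methoxycarbonyl in place of methyl on an aromatic carbon, a change that one bond further out reads as 4-methylbenzyl to 4-(methoxycarbonyl)benzyl. No measured step bears on this change; every step in the shown set is unreadable, and no measured compound has moved off the limit. The step of a number no higher from compound 3 to compound 4 (the limit leaves the size open) is therefore expected to be none beyond the scatter, with compound 4 most likely again at the limit. Compound 4 is estimated at 20000 nM, with a range from 5000 nM to 100000 nM.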

Compound 4, half-maximal inhibitory concentration: > 20000 nM
Compound 4 was reported as a limit; the forecaster's own chance of this, stated with the estimate: 80%; the middle value sits exactly at the limit.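

The steps linking compound 4 to compound 1, compound 2 and compound 3 cannot be read, so none of these four compounds can be placed ahead of another, because all of them stop at the same limit: the limit of > 20000 nM in this assay, at which 4 of the 4 values shown sit. The compounds shown leave open which change on the shared core, if any, would give a measured number, and how large that step would be.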